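This account rests on a few compounds, and the source may have more. Where it says the series, first, only, none or still open, it means among the compounds named here.

Compound 3 `O=C(Nc1cc(C(F)(F)F)cc(C(F)(F)F)c1)c1nonc1O` has the highest number of the three measured compounds in an assay on isolated protein for inhibition of mitogen-activated protein kinase kinase kinase 14 (Homo sapiens), read by ADP-Glo, with a stated time of 60 min, tested at 100 uM, in the presence of a further agent that is not named here (a lower number here means less inhibition, a higher number more inhibition at the concentration tested (going by the name of the read-out)), where compound 3 gives 19.3%. Compound 2 `Cn1nnc(O)c1C(=O)Nc1cc(C(F)(F)F)cc(C(F)(F)F)c1` gives 12.1% in this assay, and compound 1 `COc1nsnc1C(=O)Nc1cc(C(F)(F)F)cc(C(F)(F)F)c1` gives -1.9%. The three share the same core and differ only in the ring attached to the carbonyl carbon. The change from compound 1 is marked, with a number 21.2 percentage points higher from compound 1 to compound 3 (beyond the scatter) and a number 14 percentage points higher from compound 1 to compound 2 (beyond the scatter), both beyond the scatter. Between the two hydroxy-bearing rings the gap is small, a number 7.2 percentage points higher from compound 2 to compound 3 (within the scatter), within the scatter.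

Compound 4 `Cn1cc(C(=O)Nc2cc(C(F)(F)F)cc(C(F)(F)F)c2)c(O)n1` is not yet measured. It differs from compound 3 in one place: 3-hydroxy-1-methyl-1H-pyrazol-4-yl in place of 4-hydroxy-1,2,5-oxadiazol-3-yl on a carbonyl carbon

Going by the values given here, the step that bears most on this change is the one between compound 2 and compound 3, two hydroxy-bearing five-membered rings with a methyl present in one of them, which stayed within the scatter. The step from compound 1 to compound 3 shows that a ring swap can matter, but compound 1 carries no hydroxy group, and compound 4 does. Compound 4 is therefore expected to sit near compound 2 and compound 3, with an expected step of a number 6.3 percentage points lower from compound 3 to compound 4 (within the scatter), within the scatter. Compound 4 is estimated at 13%, in the range 0% to 27%.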

Compound 4, a percentage reported as inhibition, at one concentration (the size of the read-out at that concentration, not a potency): 7.23%
The estimate for compound 4 lay 5.8 percentage points above the measured number; low and high end bracket the measured number.
By their numbers in this assay, from the lowest: compounds 1, 4, 2 and 3 (each within the scatter of the next, the first and the last beyond it).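

In this assay, going by these compounds alone, placing 3-hydroxy-1-methyl-1H-pyrazol-4-yl on the carbonyl carbon instead of 4-hydroxy-1,2,5-oxadiazol-3-yl gives a number 12.1 percentage points lower from compound 3 to compound 4 (beyond the scatter), the first step between two hydroxy-bearing rings to lie beyond the scatter, so the hydroxy group alone does not make these rings interchangeable. Compound 4 cannot be told apart from compound 2, with a number 4.9 percentage points lower from compound 2 to compound 4 (within the scatter), or from compound 1, which has no hydroxy group, with a number 9.1 percentage points higher from compound 1 to compound 4 (within the scatter); the hydroxy-bearing rings of compound 2 and compound 3 do stand apart from compound 1, so compound 4 goes against any rule that a hydroxy-bearing ring separates a compound from compound 1. Nothing available here accounts for these differences between the rings.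

Open, on these data alone, is what the methyl on the ring of compound 4 contributes, and whether an amine or a carboxylic acid in place of the hydroxy group would move the number in either direction. Also open, as far as these compounds go, is how these readings at a single concentration would translate into potency.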